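From Compound 2 to Compound 3: Adding a Methoxy Group

The source may report more compounds than this note shows. Statements on the series, on what has been measured and on what is new or still open speak of the compounds shown alone.

Measured so far:
compound 1 `N#Cc1ccc(OC/C=C/c2ccccc2)cc1C#N` gives 399 nM in an assay on isolated protein for inhibition of Amine oxidase [flavin-containing] A (Homo sapiens), read by fluorescence; on this read-out higher numbers stand for weaker inhibition and lower numbers for stronger inhibition
compound 2 `N#Cc1cc2[nH]c(-c3ccccc3)c(Cl)c2cc1C#N` gives 121 nM in this assay

Of the two compounds measured, compound 2 has the lowest number, and its number lies beyond the usual scatter from that of compound 1, so compound 2 counts as the stronger inhibitor in this assay. Among the measured compounds shown here, the two compounds share no single-point difference, so what they show is only that the core of compound 2 reaches a lower number than the core of compound 1.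

Compound 3 `COc1ccc(-c2[nH]c3cc(C#N)c(C#N)cc3c2Cl)cc1` keeps the whole of compound 2 and changes it in one place: methoxy in place of hydrogen on an aromatic carbon. The group enters on an aromatic carbon of a six-membered aromatic ring of carbon only, para to a large group.

For the measured compounds named here, no measured pair in this set tells how such a change plays out, so there is no precedent to lean on. A small group added at the edge of a molecule of this kind most often shifts the number little. The step from compound 2 to compound 3 is therefore expected to be a 1.2-fold lower number from compound 2 to compound 3 (0.08 log units; within the scatter), that is, not beyond the scatter. For compound 3 the estimated value in this assay is 100 nM, with a range from 40 nM to 300 nM.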

Compound 3, half-maximal inhibitory concentration: 4 nM
For compound 3 the middle estimate is 25-fold (1.40 log units) above the measured one; the whole stated range lies above it.
By their numbers in this assay, from the lowest: compound 3; then compound 2; then compound 1.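

Replacing hydrogen with methoxy on an aromatic carbon of the six-membered aromatic ring of carbon only, para to a large group, gives a 30-fold lower number from compound 2 to compound 3 (1.48 log units; beyond the scatter), and on this read-out a lower number means stronger inhibition. Compounds 1 and 2 differ in their cores and could only show that one core reaches a lower number than the other, whereas this single-point change shows that this position on the ring strongly affects the result: adding just 2 heavy atoms, with no ring and no net charge, moves the number far beyond the usual scatter. The data shown offer no measurement that explains why this step is so large.

Going by these compounds, a single pair cannot separate the roles of the oxygen and the methyl part of methoxy, so it remains open whether a hydroxyl group, an ethoxy group or a lone fluorine atom at the same carbon would give a similar step. It also leaves open how methoxy would behave on the other carbons of this ring, and whether a longer chain or an amine would be tolerated at this position.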